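A Chloro-methylimidazolyl Group Replaces the Hydroxymethylphenyl

The compounds below may be only part of what the source reports. "The series", "measured", "known", "first", "only" and "open" are said of these compounds alone.

Of the compounds shown here, three sharing one core have so far been measured in an assay for inhibition of 15-hydroxyprostaglandin dehydrogenase [NAD(+)] (Homo sapiens), read by fluorescence, with a stated time of 15 min, in the presence of a further agent that is not named here; on this read-out higher numbers stand for weaker inhibition and lower numbers for stronger inhibition. Compound 1 `CCCC[S+]([O-])c1sc2nc(-c3nccs3)cc(-c3nccs3)c2c1N` gives 1.8 nM. Compound 2 `CCCC[S+]([O-])c1sc2nc(-c3nccs3)cc(-c3ccc(CO)cc3)c2c1N` gives 2.5 nM, the highest of the three numbers, although each of the other two lies within the scatter of it. Compound 3 `CCCC[S+]([O-])c1sc2nc(-c3nccs3)cc(-c3ccc(CNC(=O)NCC)cc3)c2c1N` gives 2.1 nM. The step of a 1.4-fold higher number from compound 1 to compound 2 (0.14 log units; within the scatter) exchanges a five-membered heteroaryl for a substituted phenyl on the same aromatic carbon, and the step of a 1.2-fold lower number from compound 2 to compound 3 (0.08 log units; within the scatter) alters only the group carried by that phenyl; neither moves the read-out beyond the scatter.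

Compound 4 `CCCC[S+]([O-])c1sc2nc(-c3nccs3)cc(-c3cnc(Cl)n3C)c2c1N` has not yet been measured. It differs from compound 2 by 2-chloro-1-methyl-1H-imidazol-5-yl in place of 4-(hydroxymethyl)phenyl on an aromatic carbon. Both earlier steps bear on this change: the first shows that swapping a five-membered heteroaryl for a phenyl at this position left the number within the scatter, and the second that the group carried there made little difference either. The step of a 1.1-fold lower number from compound 2 to compound 4 (0.04 log units; within the scatter) is therefore expected to stay within the scatter, with no clear direction. The estimate for compound 4 is 2.3 nM, with a range from 1 nM to 5.5 nM.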

Compound 4, half-maximal inhibitory concentration: 3.2 nM
For compound 4 the middle estimate is 1.4-fold (0.14 log units) below the measured one; the range from low to high includes it.
By their numbers in this assay, from the lowest: compounds 1, 3, 2 and 4 (each within the scatter of the next).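

In this assay, placing 2-chloro-1-methyl-1H-imidazol-5-yl on this aromatic carbon, opposite the ring nitrogen, gives a 1.3-fold higher number from compound 2 to compound 4 (0.11 log units; within the scatter), and the same group in place of 1,3-thiazol-2-yl gives a 1.8-fold higher number from compound 1 to compound 4 (0.25 log units; within the scatter), so a third kind of ring, a five-membered aromatic ring with 2 hetero atoms that carries a chlorine and a methyl group, also stays within the scatter. The entering group has 0 hydrogen-bond donors where 4-(hydroxymethyl)phenyl has 1, so among these compounds the loss of that donor from this position does not move the read-out beyond the scatter. Nothing available here accounts for how close these numbers lie.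

All the steps read so far at this carbon stay within the scatter, so the compounds shown do not reveal which group here, perhaps a carboxylic acid or an amine on the phenyl or a longer chain, would move the number beyond it. They also leave open what the chlorine and the methyl group each contribute, since 1-methyl-1H-imidazol-5-yl without the chlorine does not appear among them.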